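Three Measured Analogues and One Expected Cytotoxicity Value

This account rests on a few compounds, and the source may have more. Where it says the series, first, only, none or still open, it means among the compounds named here.

compound 1 `O=C(/C=C/c1ccc([N+](=O)[O-])cc1)Nc1cc2c(Nc3ccc(F)c(Cl)c3)ncnc2cc1O[C@H]1CCOC1`: 27400 nM
compound 2 `COc1cc(/C=C/C(=O)Nc2cc3c(Nc4ccc(F)c(Cl)c4)ncnc3cc2O[C@H]2CCOC2)cc(OC)c1OC`: 24500 nM
compound 3 `O=C(/C=C/c1ccc(Br)cc1)Nc1cc2c(Nc3ccc(F)c(Cl)c3)ncnc2cc1O[C@H]1CCOC1`: 27500 nM

All three were measured in a functional assay on HeLa cells (Homo sapiens) for cytotoxicity, read by MTT assay, with a stated time of 72 h; on this read-out lower numbers stand for stronger inhibition and higher numbers for weaker inhibition. Among these numbers compound 1 stands second highest; nearest to it is the step of a 1.0-fold higher number from compound 1 to compound 3 (0.00 log units; within the scatter), and furthest the step of a 1.1-fold lower number from compound 1 to compound 2 (0.05 log units; within the scatter).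

Compound 4 `O=C(/C=C/c1ccc(F)cc1Cl)Nc1cc2c(Nc3ccc(F)c(Cl)c3)ncnc2cc1O[C@H]1CCOC1` differs from compound 1 by 2-chloro-4-fluorophenyl in place of 4-nitrophenyl on a double-bonded chain carbon bound to a double-bonded chain carbon. The measured steps that bear on this change all alter the same group at the same place: a 1.1-fold lower number from compound 1 to compound 2 (0.05 log units; within the scatter), a 1.0-fold higher number from compound 1 to compound 3 (0.00 log units; within the scatter) and a 1.1-fold higher number from compound 2 to compound 3 (0.05 log units; within the scatter). None of them leaves the scatter. For compound 4, therefore, no step beyond the scatter in this assay is expected, in either direction, which means an expected step of a 1.1-fold lower number from compound 1 to compound 4 (0.02 log units; within the scatter). Compound 4 is thus estimated at 26000 nM, with a range from 12000 nM to 55000 nM.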

Compound 4, half-maximal inhibitory concentration: 37500 nM
The estimate for compound 4 lay 1.4-fold (0.16 log units) below the measured number; low and high end bracket the measured number.
By their numbers in this assay, from the lowest: compounds 2, 1, 3 and 4 (each within the scatter of the next).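

In this assay the 2-chloro-4-fluorophenyl group brings fluorine and chlorine together on the ring at this place, yet every new step stays within the scatter (a 1.4-fold higher number from compound 1 to compound 4 (0.14 log units; within the scatter)) (a 1.4-fold higher number from compound 3 to compound 4 (0.13 log units; within the scatter)) (a 1.5-fold higher number from compound 2 to compound 4 (0.18 log units; within the scatter)). Across the four compounds, this position therefore accepts all four substituted phenyl groups without a step that leaves the scatter. Nothing available explains this result. The compounds shown leave open whether an amine or a carboxylic acid on this ring would leave the scatter. They also leave open what a saturated alkyl chain in place of the ring would do.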